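From a bare nitrogen to a 4-methylphenyl group

The source may hold more compounds than are shown below. What is called first, only, known or untested is meant among the compounds shown, and "the series" means these compounds.

Measured compounds:
compound 1, `NC(=S)N/N=C/c1ccc2ccccc2n1`, gives 100000 nM
compound 2, `NC(=S)N/N=C/c1cc2ccccc2s1`, gives 99200 nM
compound 3, `CC(C)c1cccc(C(C)C)c1NC(=S)N/N=C/c1ccc2ccccc2n1`, gives 20700 nM

These three numbers come from a functional assay on HT-29 cells (Homo sapiens) for antiproliferative activity, read by sulforhodamine B assay, with a stated time of 72 h; a lower number here means a stronger inhibitor, a higher number a weaker inhibitor. Compound 1 stands at the highest of the three values, meaning the weakest inhibition recorded so far. Compound 2 sits next to it, and the gap between the two lies within the usual scatter, so no order can be read between them. Compound 3 is the furthest away, with a number well below that of compound 1, a gap that lies beyond the scatter; compound 3 carries a substituted phenyl group on the amide-type nitrogen where compound 1 carries only a hydrogen atom.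

Compound 4, `Cc1ccc(NC(=S)N/N=C/c2ccc3ccccc3n2)cc1`, has not yet been measured. It differs from compound 1 in one place: 4-methylphenyl in place of hydrogen on an amide-type nitrogen. This is the same kind of change that sets compound 3 apart from compound 1, with a different group entering.

Since compound 3 already shows that replacing the hydrogen on that nitrogen with a carbon ring lowers the number, the step from compound 1 to compound 4 is expected to go in the same direction, toward a lower value, by an amount beyond the scatter but of uncertain size. For compound 4 the expected value is 30000 nM, within the range 10000 nM to 100000 nM, corresponding to an estimated step of a 3.3-fold lower number from compound 1 to compound 4 (0.52 log units; beyond the scatter).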

Compound 4, half-maximal inhibitory concentration: 85500 nM
Beside the measured number, compound 4's estimate is 2.9-fold (0.45 log units) below it; the measured number falls inside the stated range.
By their numbers in this assay, from the lowest: compound 3; then compounds 4, 2 and 1 (each within the scatter of the next).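

In this assay, putting 4-methylphenyl in place of hydrogen on the amide-type nitrogen gives a 1.2-fold lower number from compound 1 to compound 4 (0.07 log units; within the scatter), so this change shows no real effect on the number. Compound 3 gives 20700 nM and compound 4 gives 85500 nM, so a carbon ring on this nitrogen does not lower the number by itself, and the outcome depends on which substituted phenyl group enters, the one difference between these two compounds. Nothing measured here explains why these two groups give different numbers.

The compounds shown leave open what an unsubstituted phenyl ring, a 4-methoxyphenyl group or an open chain such as hexyl would do on this nitrogen, and so how much of the lower number of compound 3 depends on the particular groups carried by its ring. They also leave open whether the same change would give a similar result on the core of compound 2, since here only the core of compound 1 carries a group on this nitrogen.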